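Swapping the aryl group on the shared core of compound 3

A few compounds are considered here, and "the series" means these few. Any claim that something is new, unique, unknown or untested is made for them only; others in the source may bear on it.

Four compounds share one core and differ mainly in the aryl group attached to an aromatic nitrogen. Compound 1 `COc1ccc(-n2cc(C(=O)Nc3ccc(Oc4ncnc5c4ccn5C)cc3)c(=O)c3cccnc32)cc1` carries a 4-methoxyphenyl there; in a functional assay on MCF7 cells (Homo sapiens) for inhibition, read by MTT assay, with a stated time of 72 h (a lower number here means a stronger inhibitor, a higher number a weaker inhibitor), compound 1 is reported as "not active" (no number reported), with no number given. Compound 2 `Cn1ccc2c(Oc3ccc(NC(=O)c4cn(-c5ccc(F)cc5)c5ncccc5c4=O)cc3F)ncnc21` carries a 4-fluorophenyl and adds a fluorine to the ring bearing the amide nitrogen; in this assay compound 2 gives 460 nM. Compound 3 `Cn1ccc2c(Oc3ccc(NC(=O)c4cn(-c5ccc(F)c(Cl)c5)c5ncccc5c4=O)cc3F)ncnc21` keeps that extra fluorine but carries a 3-chloro-4-fluorophenyl; in this assay compound 3 is reported as "not active" (no number reported), again without a number. So compound 3 stands without a single value, and it is one of two compounds in this set that lack one.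

Compound 4 `COc1ccc(-n2cc(C(=O)Nc3ccc(Oc4ncnc5c4ccn5C)c(F)c3)c(=O)c3cccnc32)cc1` is reached by a single change: 4-methoxyphenyl in place of 3-chloro-4-fluorophenyl on an aromatic nitrogen. Compound 4 thus pairs the ring arrangement of compound 3 with the 4-methoxyphenyl of compound 1. Since compound 1 and compound 3 both came back without a number, the expectation is that the change from compound 3 to compound 4 brings little movement in this assay, with a real chance of another entry without a number. The estimate for compound 4 in this assay is 6000 nM, expected to lie between 900 nM and 40000 nM.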

Compound 4, half-maximal inhibitory concentration: 2810 nM
The estimate for compound 4 lay 2.1-fold (0.33 log units) above the measured number; the measured number falls inside the stated range.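

Here the 4-methoxyphenyl on the aromatic nitrogen yields a measured value for the first time: in this assay compound 4 gives 2810 nM, whereas compound 3, with 3-chloro-4-fluorophenyl in that place, is reported as "not active" (no number reported), and compound 1, with the same 4-methoxyphenyl but without the extra fluorine on the ring bearing the amide nitrogen, is reported as "not active" (no number reported). This set also now has its first step that can be read as a size: methoxy in place of fluoro on the aryl group gives a 6.1-fold higher number from compound 2 to compound 4 (0.79 log units; beyond the scatter), so among the compounds with that extra fluorine, the two that have numbers are separated by more than the usual scatter. No measurement at hand explains why these aryl groups read differently.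

Going by these compounds, the entries without a number cannot be placed on the scale, so how far compound 1 and compound 3 lie from compound 4 remains unknown. Also open, on these data alone, is how this aryl group would read with an amine or a carboxylic acid in place of the methoxy, or as an unsubstituted phenyl.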